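This account rests on a few compounds, and the source may have more. Where it says the series, first, only, none or still open, it means among the compounds named here.

Compound 1 `COc1ccc(C2N=C(SCc3ccccc3)NC(C)=C2C(=O)Nc2ccc(F)cc2)cc1OC`: 7.2%
Compound 2 `COc1ccc(C2N=C(SCc3ccccc3Cl)NC(C)=C2C(=O)Nc2ccc(F)cc2)cc1OC`: 35.9%

Within the data shown here, in a functional assay on the whole organism (artery, strain albino) with Rattus norvegicus as the target, with a stated time of 300 min, at a dose of 10 mg/kg by the oral route (on this read-out lower numbers stand for less inhibition and higher numbers for more inhibition at the one dose given (going by the name of the read-out)), compound 2 has the higher of the two numbers so far. Among the measured compounds shown here, its only measured neighbour is compound 1, and the step of a number 28.7 percentage points higher from compound 1 to compound 2 (beyond the scatter) lies beyond the usual scatter, so compound 2 stands clearly above compound 1 on this read-out.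

Compound 3 `COc1ccc(C2N=C(SCc3ccc(F)cc3)NC(C)=C2C(=O)Nc2ccc(F)cc2)cc1OC` has not yet been measured. It differs from compound 2 in a single place: 4-fluorophenyl in place of 2-chlorophenyl on a saturated chain carbon bound to a sulfur.

For the measured compounds named here, only one measured step bears on this change, namely a number 28.7 percentage points higher from compound 1 to compound 2 (beyond the scatter), which shows how much the single added chloro raised the read-out. Going by the values given here, no measured pair shows what happens when that chloro gives way to a fluoro at a different place on the same ring, so both the direction and the size of the coming step are uncertain. The step from compound 2 to compound 3 is therefore expected to be small or downward, estimated at a number 15.9 percentage points lower from compound 2 to compound 3 (beyond the scatter). For compound 3 the expected value is 20%, with a likely range from 3% to 42%.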

Compound 3, a percentage reported as inhibition, in the whole organism at one dose (the size of the read-out at that dose, not a potency): 37.9%
For compound 3 the middle estimate is 17.9 percentage points below the measured one; measured number inside the range.
By their numbers in this assay, from the lowest: compound 1; then compounds 2 and 3 (each within the scatter of the next).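

Compound 3 carries 4-fluorophenyl where compound 2 carries 2-chlorophenyl, and in this assay the two cannot be told apart, with a number 2 percentage points higher from compound 2 to compound 3 (within the scatter). Compound 1 has no substituent on this ring, and fluoro in place of hydrogen gives a number 30.7 percentage points higher from compound 1 to compound 3 (beyond the scatter), so the rise seen earlier with chloro is not tied to chloro alone: among these three compounds, both rings bearing a halogen stand clearly above the ring without one. No measurement is available that explains this result.

Compounds 2 and 3 differ in both the halogen and its place on the ring, so these compounds cannot separate the effect of the element from the effect of where it sits; a chloro and a fluoro at the same ring place would be needed for that. On these data alone, it also remains open whether a halogen is needed at all, which an amine or a methoxy group on this ring could test, and whether a longer chain between the sulfur and the ring would keep the higher numbers.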